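A Methyl on the Benzyl Arm of Compound 3

The source may report more compounds than this note shows. Statements on the series, on what has been measured and on what is new or still open speak of the compounds shown alone.

Three compounds have been measured in a functional assay on RAW264.7 cells (Mus musculus) for inhibition, read by Griess assay, with stated times of 1 h and 24 h; on this read-out higher numbers stand for weaker inhibition and lower numbers for stronger inhibition:
compound 1 `COc1ccc(Nc2nc(/C=C/c3cc(OC)c(OC)c(OC)c3)nc3ccsc23)cc1`: 10700 nM
compound 2 `COc1cc(/C=C/c2nc(Nc3ccc(C(F)(F)F)cc3)c3sccc3n2)cc(OC)c1OC`: 9360 nM
compound 3 `COc1cc(/C=C/c2nc(NCc3ccccc3)c3sccc3n2)cc(OC)c1OC`: 8260 nM

Compound 3 carries the lowest of the three numbers, yet the steps of a 1.3-fold lower number from compound 1 to compound 3 (0.11 log units; within the scatter) and a 1.1-fold lower number from compound 2 to compound 3 (0.05 log units; within the scatter) both lie within the scatter, so no ordering among them is secure. Compound 4 `COc1cc(/C=C/c2nc(NCc3ccc(C)cc3)c3sccc3n2)cc(OC)c1OC` differs from compound 3 by methyl in place of hydrogen on an aromatic carbon. Among the compounds with values here, no measured step alters this ring; the nearest comparison, a swap of substituents on an aromatic carbon in a 1.1-fold lower number from compound 1 to compound 2 (0.06 log units; within the scatter), stayed within the scatter, as did a 1.1-fold lower number from compound 2 to compound 3 (0.05 log units; within the scatter). For compound 4 the step of a 1.1-fold lower number from compound 3 to compound 4 (0.04 log units; within the scatter) is therefore expected to remain within the scatter. Compound 4 is estimated at 7500 nM, with a range from 3500 nM to 16000 nM.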

Compound 4, half-maximal inhibitory concentration: 1860 nM
Beside the measured number, compound 4's estimate is 4.0-fold (0.61 log units) above it; measured number outside the range, below it.
By their numbers in this assay, from the lowest: compound 4; then compounds 3, 2 and 1 (each within the scatter of the next).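

In this assay, within the data shown here, methyl in place of hydrogen on the benzyl ring, para to a large group, gives a 4.4-fold lower number from compound 3 to compound 4 (0.65 log units; beyond the scatter) and so moves the number beyond the scatter, which no earlier step did. Against the aryl groups on the nitrogen, 4-methylbenzyl likewise gives a 5.0-fold lower number from compound 2 to compound 4 (0.70 log units; beyond the scatter) and a 5.8-fold lower number from compound 1 to compound 4 (0.76 log units; beyond the scatter) where benzyl stayed within the scatter of both. Nothing available explains why this one methyl has such an effect.

As far as these compounds go, whether ethyl, a chlorine atom or an amine at this same carbon would match the methyl remains open. So does whether a longer chain there would lower the number further.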